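A hydroxy group added to compound 1

The source may report more compounds than this note shows. Statements on the series, on what has been measured and on what is new or still open speak of the compounds shown alone.

Measured so far in an ADME assay on MT4 cells (Homo sapiens) for cytotoxicity, read by MTT assay, with a stated time of 4 days; on this read-out lower numbers stand for higher toxicity in this test and higher numbers for lower toxicity in this test:
compound 1 `C/C(=N\NC(=O)COc1cccc2ccccc12)c1ccccc1` gives 105 ug/mL
compound 2 `O=C(COc1cccc2ccccc12)N/N=C/c1ccc(Br)cc1` gives 106 ug/mL

Going by the values given here, compound 1 and compound 2 lie within the usual scatter of each other, so neither can be ranked against the other, and compound 1 stands level with the only other number known. The next compound to be tested, compound 3 `C/C(=N\NC(=O)COc1cccc2ccccc12)c1ccccc1O`, keeps the core of compound 1 and alters it in one place. Phenyl becomes 2-hydroxyphenyl (hydroxy in place of hydrogen on an aromatic carbon), with hydroxy in place of hydrogen on an aromatic carbon, ortho to a large group. Among the compounds with values here, no measured pair isolates this change in this assay, so any expectation is loose. Starting from compound 1 at 105 ug/mL, a moderate move toward a lower number is expected, although a result within the scatter remains quite possible. The expected size of the move is an estimated 1.8-fold lower number from compound 1 to compound 3 (0.24 log units; within the scatter). For compound 3 the estimated value is 60 ug/mL, with an expected range from 15 ug/mL to 125 ug/mL.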

Compound 3, half-maximal cytotoxic concentration: 11.3 ug/mL
The estimate for compound 3 lay 5.3-fold (0.73 log units) above the measured number; measured number below the stated range.
By their numbers in this assay, from the lowest: compound 3; then compounds 1 and 2 (each within the scatter of the next).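

In this assay, hydroxy in place of hydrogen on an aromatic carbon, ortho to a large group, gives a 9.3-fold lower number from compound 1 to compound 3 (0.97 log units; beyond the scatter), so this position on the phenyl group of compound 1 is one where a single added hydroxy moves the read-out beyond the scatter, toward higher toxicity in this test. Going by these compounds alone, the two earlier numbers lay within the scatter of each other and showed no change that could shift this read-out; this pair is the first to show one, and its direction is toward the lower number. Within the data shown here, nothing measured so far accounts for the size or direction of this step.

The compounds shown leave open whether the hydroxy itself matters here or whether another group at the same place, such as methoxy, an amine or fluorine, would give a similar step. They also leave open whether hydroxy on another carbon of the same ring, or on the bromophenyl group of compound 2, would lower the number as it does in compound 3.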